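The compounds below may be only part of what the source reports. "The series", "measured", "known", "first", "only" and "open" are said of these compounds alone.

Of the compounds shown here, three with a shared core have been tested in an assay on cells for inhibition of HSP60/HSP10 (Homo sapiens), with a stated time of 60 min; a lower number here means a stronger inhibitor, a higher number a weaker inhibitor. Compound 1 `O=S(=O)(Nc1ccc(-c2nc3ccccc3o2)cc1)c1ccccc1C(F)(F)F` gives 74000 nM in this assay. Compound 2 `O=S(=O)(Nc1ccc(-c2nc3ccccc3o2)cc1)c1ccccc1O` differs from compound 1 by a hydroxy in place of trifluoromethyl on an aromatic carbon; in this assay compound 2 reaches only the limit of the assay, > 100000 nM, so no number is known for it. Compound 3 `O=S(=O)(Nc1ccc2oc(-c3ccccc3)nc2c1)c1cccc(C(F)(F)F)c1` likewise reaches only the limit, > 100000 nM, in this assay. Compound 2 thus stands at a limit, a place it shares with one other value: the limit of > 100000 nM in this assay, at which 2 of the 3 values shown sit. Going by the values given here, the one measured step is an at least 1.3-fold higher number from compound 1 to compound 2 (0.13 log units; that floor lies within the scatter). Compound 4 `CCc1ccc(S(=O)(=O)Nc2ccc(-c3nc4ccccc4o3)cc2)cc1` is not yet measured; it differs from compound 2 as follows: 4-ethylphenyl in place of 2-hydroxyphenyl on a sulfonyl sulfur. Among the compounds with values here, no measured step exchanges one aryl group on the sulfonyl sulfur for another, so the step from compound 1 to compound 2 bears only loosely on this change, and every value known here lies toward the weak end of this assay. Compound 4 is therefore expected to stay near the limit, with an expected step of an at least 1.1-fold lower number from compound 2 to compound 4 (0.04 log units; that floor lies within the scatter), a size within the scatter. For compound 4 the estimated value in this assay is 90000 nM, with a range from 30000 nM to 300000 nM.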

Compound 4, half-maximal inhibitory concentration: > 100000 nM
Compound 4: a limit, no number (the forecaster's own chance of this, stated with the estimate: 55%); middle value at least 1.1-fold (0.04 log units) away from the limit.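

In this assay compound 4 gives > 100000 nM, which is a limit and not a number. Compound 2 also stands at a limit, so no step can be read between compound 2 and compound 4: the limit of > 100000 nM in this assay, at which 3 of the 4 values shown sit.

The compounds shown leave open whether 4-ethylphenyl in place of 2-hydroxyphenyl on a sulfonyl sulfur changes the strength of inhibition at all.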